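The source may report more compounds than this note shows. Statements on the series, on what has been measured and on what is new or still open speak of the compounds shown alone.

In a physicochemical assay for lipophilicity, at pH 7.4 (on this read-out lower numbers stand for lower lipophilicity and higher numbers for higher lipophilicity), compound 3 `CNC(=O)c1cc(C(=O)NC2CC2)cn(CC2CCCCC2)c1=O` gives 4, the highest of the three numbers in hand; compound 1 `CNC(=O)c1cc(C(=O)NC2CC2)cn(Cc2ccc3nc[nH]c3c2)c1=O` gives 1.2 and compound 2 `CNC(=O)c1cc(C(=O)NC2CC2)cn(Cc2cccc3[nH]ncc23)c1=O` gives 1.5. Compound 4 `CNC(=O)c1cc(C(=O)NC2CC2)cn(Cc2cccc3c2CCN3)c1=O` differs from compound 3 as follows: 2,3-dihydro-1H-indol-4-yl in place of cyclohexyl on a saturated chain carbon bound to an aromatic nitrogen. Going by the values given here, two measured steps bear on this change and both run the opposite way: a number 2.80 log units higher from compound 1 to compound 3 (beyond the scatter) and a number 2.50 log units higher from compound 2 to compound 3 (beyond the scatter), each large. The group entering compound 4 again carries a hydrogen-bond donor and an aromatic ring, as the groups in compound 1 and compound 2 do, so a large fall in the same assay is expected, though not the whole way back; the step of a number 1.70 log units lower from compound 3 to compound 4 (beyond the scatter) is estimated. Compound 4 is thus expected at 2.3, with a range of 1.6 to 3.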

Compound 4, distribution coefficient: 2.1
Compound 4: middle estimate off by 0.20 log units, on the high side; the range from low to high includes it.
By their numbers in this assay, from the lowest: compounds 1 and 2 (each within the scatter of the next); then compound 4; then compound 3.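

In this assay, this position now shows a third level: 2,3-dihydro-1H-indol-4-yl in place of cyclohexyl still gives a large fall (a number 1.90 log units lower from compound 3 to compound 4 (beyond the scatter)), yet it stays apart from the other two groups (a number 0.60 log units higher from compound 2 to compound 4 (beyond the scatter); a number 0.90 log units higher from compound 1 to compound 4 (beyond the scatter)). A hydrogen-bond donor and an aromatic ring in the entering group therefore do not alone set the number across compound 1, compound 2 and compound 4. No measurement in hand accounts for these gaps.

Open, going by these compounds, is how an amine or a carboxylic acid on the entering ring would read in this assay. On these data alone, a longer chain at this position is equally open.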